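The compounds below may be only part of what the source reports. "The series", "measured", "known", "first", "only" and "open" are said of these compounds alone.

Measured so far in an ADME assay for permeability, using PAMPA, with a stated time of 30 min, at pH 7.4; on this read-out lower numbers stand for lower permeability and higher numbers for higher permeability:
- compound 1 `c1ccc(Oc2ccc3c(NCCCNCc4ccco4)ccnc3c2)cc1`: 317 10^-6 cm/s
- compound 2 `COc1ccccc1Oc1ccc2c(NCCCNCc3ccco3)ccnc2c1`: 317 10^-6 cm/s

Level with compound 1, compound 2 stands at 317 10^-6 cm/s. The next structure is compound 3 `Clc1ccc(Oc2ccc3c(NCCCNCc4ccco4)ccnc3c2)cc1`, with 4-chlorophenyl in place of 2-methoxyphenyl on an oxygen on an aromatic ring.

Among the measured compounds shown here, only one measured step bears on this change: no change at the digits printed from compound 1 to compound 2 (within the scatter), with methoxy in place of hydrogen on an aromatic carbon. That step involves the methoxy that now leaves. For the measured compounds named here, no measured compound carries chlorine, so the entering group has no direct precedent in this small set. With so little to go on, no step beyond the scatter is expected in this assay. The expected step is a 1.0-fold lower number from compound 2 to compound 3 (0.01 log units; within the scatter). The estimate for compound 3 is 310 10^-6 cm/s, with an expected range of 180 10^-6 cm/s to 520 10^-6 cm/s.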

Compound 3, apparent permeability: 317 10^-6 cm/s
Estimate against measurement, compound 3: 1.0-fold (0.01 log units) below; measured number inside the range.
By their numbers in this assay, from the lowest: compounds 1, 2 and 3 (each within the scatter of the next).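

Replacing 2-methoxyphenyl with 4-chlorophenyl on an oxygen on an aromatic ring gives no change at the digits printed from compound 2 to compound 3 (within the scatter) in this assay and shows that this exchange of both the group and its printed name position leaves the read-out unmoved. Chloro in place of hydrogen on an aromatic carbon gives no change at the digits printed from compound 1 to compound 3 (within the scatter) so the series now has two different substituents on this ring, methoxy and chloro, each level with the hydrogen of compound 1, and no listed compound goes against this. No supporting evidence bears on why the values stay level.

From the compounds shown here alone, whether this flat reading holds for a carboxylic acid or a primary amine on the same ring remains open. Also open, going by these compounds, is whether 2-chlorophenyl or 4-methoxyphenyl would read the same, which would separate the group from its placement.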